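A Larger Silicon-Containing Group and Cytotoxicity in Col2 Cells

This account rests on a few compounds, and the source may have more. Where it says the series, first, only, none or still open, it means among the compounds named here.

Three compounds were measured in a functional assay on Col2 cells (Homo sapiens) for cytotoxicity, read by sulforhodamine B assay; on this read-out lower numbers stand for an effect already at smaller amounts and higher numbers for an effect only at larger amounts of compound:
Compound 1, `C=C1CC[C@@H]2[C@](C)(CO[Si](C(C)C)(C(C)C)C(C)C)[C@H](OC(C)=O)CC[C@@]2(C)[C@@H]1C/C=C1/C(=O)OC[C@H]1OC(C)=O`, gives 13.6 uM.
Compound 2, `C=C1CC[C@@H]2[C@](C)(CO[Si](C)(C)C(C)(C)C)[C@H](OC(C)=O)CC[C@@]2(C)[C@@H]1C/C=C1/C(=O)OC[C@H]1OC(C)=O`, gives 2.23 uM.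
Compound 3, `C=C1CC[C@@H]2[C@](C)(CO[Si](C)(C)C(C)(C)C)[C@H](O)CC[C@@]2(C)[C@@H]1C/C=C1/C(=O)OC[C@H]1O`, gives 17.1 uM.

Compound 1 and compound 2 share one core and differ only by a group of 10 heavy atoms (9 carbon, 1 silicon; no ring) in place of a group of 7 heavy atoms (6 carbon, 1 silicon; no ring), on an oxygen on a saturated carbon. This change produced a 6.1-fold higher number from compound 2 to compound 1 (0.79 log units; beyond the scatter). Compound 3 carries a different core; how the core of compound 3 differs from that of compound 2 is not broken down here. In this assay compound 3 and compound 1 lie within the scatter of each other, while compound 2 gives a lower number than both, and that gap is beyond the scatter.

Compound 4, `C=C1CC[C@@H]2[C@](C)(CO[Si](C(C)C)(C(C)C)C(C)C)[C@H](O)CC[C@@]2(C)[C@@H]1C/C=C1/C(=O)OC[C@H]1O`, has not yet been measured. It differs from compound 3 by a group of 10 heavy atoms (9 carbon, 1 silicon; no ring) in place of a group of 7 heavy atoms (6 carbon, 1 silicon; no ring), on an oxygen on a saturated carbon. The surroundings of the place are the same in words as for the change from compound 2 to compound 1, so it is the same change, made on the core of compound 3 rather than that of compound 2.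

Compound 4 is expected to give a higher number than compound 3 by a step of about a 3.5-fold higher number from compound 3 to compound 4 (0.55 log units; beyond the scatter), because the same change gave a 6.1-fold higher number from compound 2 to compound 1 (0.79 log units; beyond the scatter). That expectation rests on a single earlier step on a different core, so the transfer is uncertain. Compound 4 is therefore estimated at 60 uM in this assay, with a likely range from 20 uM to 150 uM, and there is a real chance that the assay reports only a limit for it.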

Compound 4, concentration for half-maximal effect: 2.73 uM
Compound 4: middle estimate off by 22-fold (1.34 log units), on the high side; the measured number lies below the stated range.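

In this assay, putting the group of 10 heavy atoms in place of the group of 7 heavy atoms on the core of compound 3 gave a 6.3-fold lower number from compound 3 to compound 4 (0.80 log units; beyond the scatter), so the same change ran in the opposite direction from the one seen on the core of compound 1, and the two steps clearly differ: the same change on two cores in this assay, a 6.1-fold higher number (0.79 log units; beyond the scatter) from compound 2 to compound 1 and a 6.3-fold lower number (0.80 log units; beyond the scatter) from compound 3 to compound 4, 38-fold (1.58 log units) apart, beyond the scatter of two such steps

This shows that, for these two pairs, neither the direction nor the size of the step carries from one core to the other, so a step read on one core is no safe guide to the result on the other. Among these compounds, it does not show what in the cores causes the reversal, and with only two pairs it does not establish a rule for any further core.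

The compounds shown leave open how other groups on that oxygen would behave on each core, for example a trimethylsilyl group, a benzyl group or a plain methyl ether. They also leave open which of the differences between the two cores goes with the reversal, since the acetyl esters of compound 1 and the free hydroxyl groups of compound 4 are not separated by any compound with only one of them changed.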